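Exchanging the Chlorophenyl Amide: Expectation for Compound 3

The source may hold more compounds than are shown below. What is called first, only, known or untested is meant among the compounds shown, and "the series" means these compounds.

Measured compounds:
compound 1 `O=C(/C=C/c1cccc(NC(=O)c2ccccc2Cl)c1)c1nc2ccccc2[nH]1` — 3690 nM
compound 2 `COc1ccc(C(=O)Nc2cccc(/C=C/C(=O)c3nc4ccccc4[nH]3)c2)cc1` — 6330 nM

In a functional assay on 143B cells (Homo sapiens) for antiproliferative activity, read by MTT assay, with a stated time of 48 h (on this read-out lower numbers stand for stronger inhibition and higher numbers for weaker inhibition), compound 1 gives 3690 nM. Compound 2, in this assay, gives 6330 nM, and the one step joining them, a 1.7-fold higher number from compound 1 to compound 2 (0.23 log units; within the scatter), stays within the scatter, so on the numbers shown compound 1 and compound 2 stand as equals. Compound 3 `Cc1cc(C)cc(C(=O)Nc2cccc(/C=C/C(=O)c3nc4ccccc4[nH]3)c2)c1` differs from compound 1 in one place: 3,5-dimethylphenyl in place of 2-chlorophenyl on a carbonyl carbon. Among the compounds with values here, the one measured step that bears on this change is a 1.7-fold higher number from compound 1 to compound 2 (0.23 log units; within the scatter), another exchange of the 2-chlorophenyl on the carbonyl carbon for a different ring, and it did not leave the scatter. Compound 3 is therefore expected to show no step beyond the scatter, a 1.2-fold higher number from compound 1 to compound 3 (0.09 log units; within the scatter). Compound 3 is estimated at 4500 nM, with a range from 2000 nM to 10000 nM.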

Compound 3, half-maximal inhibitory concentration: 4020 nM
The estimate for compound 3 lay 1.1-fold (0.05 log units) above the measured number, and the stated range covers the measured number.
By their numbers in this assay, from the lowest: compounds 1, 3 and 2 (each within the scatter of the next).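

In this assay the step of a 1.1-fold higher number from compound 1 to compound 3 (0.04 log units; within the scatter) stays within the scatter, and so does the step of a 1.6-fold lower number from compound 2 to compound 3 (0.20 log units; within the scatter) on the same carbonyl carbon. Within the data shown here, with 2-chlorophenyl, 4-methoxyphenyl and 3,5-dimethylphenyl now compared at this position, no pair among the three compounds separates, so this exchange of one six-membered aromatic ring of carbon only for another has not yet moved the number beyond the scatter. Nothing available accounts for this flat result.

Every group shown at this position is such a ring, so it remains open whether an amine, a carboxylic acid or a longer chain on this carbonyl carbon would leave the scatter. Going by these compounds, it also remains open whether a change elsewhere in the core of compound 1 would do so.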